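Flipping the central ring stereocentres of compound 1

The source may hold more compounds than are shown below. What is called first, only, known or untested is meant among the compounds shown, and "the series" means these compounds.

Among the compounds with values here, compound 1 `COC(=O)N[C@H](C(=O)N1CCC[C@H]1C(=O)Nc1ccc([C@H]2CC[C@H](c3ccc(NC(=O)[C@@H]4CCCN4C(=O)[C@@H](NC(=O)OC)C(C)C)cc3)N2c2ccc(C(F)(F)F)cc2)cc1)C(C)C` is the least soluble of the three measured members: in a physicochemical assay for solubility, in phosphate buffer, measured as kinetic solubility, at pH 7.2 (a higher number here means a more soluble compound, a lower number a less soluble compound), compound 1 gives 3200 nM. Compound 3 `COC(=O)N[C@H](C(=O)N1CCC[C@H]1C(=O)Nc1ccc([C@H]2CC[C@H](c3ccc(NC(=O)[C@@H]4CCCN4C(=O)[C@@H](NC(=O)OC)C(C)C)cc3)N2c2ccc(F)cc2)cc1)C(C)C`, which carries fluoro in place of trifluoromethyl on an aromatic carbon, gives 6000 nM, and the step of a 1.9-fold higher number from compound 1 to compound 3 (0.27 log units; within the scatter) stays within the scatter. Within the data shown here, compound 2 `COC(=O)N[C@H](C(=O)N1CCC[C@H]1C(=O)Nc1ccc([C@@H]2CC[C@@H](c3ccc(NC(=O)[C@@H]4CCCN4C(=O)[C@@H](NC(=O)OC)[C@@H](C)OC)cc3)N2c2ccc(F)cc2)cc1)[C@@H](C)OC` gives 9600 nM; no single-change step connects it to compound 1.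

Compound 4 `COC(=O)N[C@H](C(=O)N1CCC[C@H]1C(=O)Nc1ccc([C@@H]2CC[C@@H](c3ccc(NC(=O)[C@@H]4CCCN4C(=O)[C@@H](NC(=O)OC)C(C)C)cc3)N2c2ccc(C(F)(F)F)cc2)cc1)C(C)C` differs from compound 1 only in configuration: the two compounds have the same atoms and bonds and differ only in configuration as drawn: 2 of 6 stereo elements differ; a stereocentre at a saturated ring carbon is drawn R in compound 1 and S in compound 4; a stereocentre at a saturated ring carbon is drawn R in compound 1 and S in compound 4. Among the measured compounds shown here, no measured step in this set isolates a change of configuration alone; compound 2 shares the drawn configuration of compound 4 at these two centres but differs from compound 1 in several other places, so its value carries no direct weight here. For the measured compounds named here, the step from compound 1 to compound 3, within the scatter, is the only neighbouring step and does not bear on configuration. With no evidence for a direction, compound 4 is expected to show no change at the digits printed from compound 1 to compound 4 (within the scatter), a change within the scatter. Compound 4 is therefore estimated at 3200 nM, with a range from 1400 nM to 7500 nM.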

Compound 4, solubility: 3400 nM
Beside the measured number, compound 4's estimate is 1.1-fold (0.03 log units) below it; the measured number falls inside the stated range.
By their numbers in this assay, from the lowest: compounds 1, 4, 3 and 2 (each within the scatter of the next, the first and the last beyond it).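

In this assay the inversion of both saturated ring carbons gives a 1.1-fold higher number from compound 1 to compound 4 (0.03 log units; within the scatter) and so does not separate the two compounds. Within the data shown here, the one earlier step changed only the group on the aromatic carbon and did not bear on these two centres, so with trifluoromethyl on that carbon the drawn configuration at these centres now has a direct reading, and it is flat within the scatter. This is the first step in the set that isolates configuration: the fact that compounds 1 and 4 differ only in the configuration as drawn

As far as these compounds go, whether the same inversion reads the same way with fluoro on the aromatic carbon, or when only one of the two centres is inverted, stays open. Also open, from the compounds shown here alone, is how either configuration reads with a carboxylic acid or a primary amine on that aromatic carbon.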